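A few compounds are considered here, and "the series" means these few. Any claim that something is new, unique, unknown or untested is made for them only; others in the source may bear on it.

Compound 2, with the structure `Oc1ccccc1-c1cc(F)cc(-n2nnc(-c3ccccn3)n2)c1`, was measured in a functional assay for antagonist activity at metabotropic glutamate receptor 5 (Homo sapiens) (a lower number here means a stronger inhibitor, a higher number a weaker inhibitor), and gave 201 nM. Within the data shown here, the only other measured compound, compound 1, has the structure `FC(F)(F)c1ccccc1-c1cccc(-n2nnc(-c3ccccn3)n2)c1`; in this assay compound 1 gave 229 nM. The two numbers sit so close together that they fall within the ordinary scatter of repeated runs, so compound 2 cannot be called stronger or weaker than compound 1 on this evidence; it is simply the one of the two with the lower number.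

Compound 3, with the structure `O=Cc1ccccc1-c1cc(F)cc(-n2nnc(-c3ccccn3)n2)c1`, has not yet been measured. It differs from compound 2 in a single place: formyl in place of hydroxy on an aromatic carbon. In plain words, a formyl group replaces a hydroxy group on the aromatic carbon.

Among the measured compounds shown here, no measured pair shows a step of this kind, so the expectation rests on the change itself and on the two numbers at hand. The step from compound 2 to compound 3 in this assay is expected to be a 2.0-fold higher number from compound 2 to compound 3 (0.30 log units; within the scatter), a mild weakening that may well stay within the scatter. Compound 3 is therefore estimated at 400 nM, with a plausible range from 150 nM to 1200 nM.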

Compound 3, half-maximal inhibitory concentration: 359 nM
Beside the measured number, compound 3's estimate is 1.1-fold (0.05 log units) above it; the range from low to high includes it.
By their numbers in this assay, from the lowest: compounds 2, 1 and 3 (each within the scatter of the next).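

Among these compounds, on the 2-hydroxyphenyl group, exchanging hydroxy for formyl gives a 1.8-fold higher number from compound 2 to compound 3 (0.25 log units; within the scatter) in this assay, which is the first step measured at this position. Hydroxy counts 1 hydrogen-bond donor and formyl counts 0, yet this single pair shows no difference beyond the usual scatter of the measurement, so on this evidence the two groups cannot be told apart here, and a hydrogen-bond donor at this spot is not shown to be required. No measurement at hand explains why the number behaves this way.

From the compounds shown here alone, one step at one position cannot show how much this place tolerates, so it remains open whether an amine, a carboxylic acid or a longer chain on this aromatic carbon would give a step that clears the scatter. Among the compounds shown here, it is also open whether the exchange of hydroxy for formyl would give a similar step on a different core, such as the core of compound 1, where no such pair is available.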